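A few compounds are considered here, and "the series" means these few. Any claim that something is new, unique, unknown or untested is made for them only; others in the source may bear on it.

Compound 2 `O=c1cc(CSC(=S)N2CCCC2)oc2ccccc12`: 23100 nM
Compound 1 `O=c1cc(CSC(=S)N2CCCCC2)oc2cc(Cl)ccc12`: a limit of the assay, > 25000 nM
Compound 3 `O=c1cc(CSC(=S)N2CCCC2)oc2cc(Cl)ccc12`: a limit of the assay, > 40000 nM

Going by the values given here, in a functional assay on HeLa cells (Homo sapiens) for antiproliferative activity, read by MTT assay, with a stated time of 72 h (a lower number here means a stronger inhibitor, a higher number a weaker inhibitor), compound 2 stands as the only compound with an actual number; the two other values are limits. Compound 4 `O=c1c(Cl)c(CSC(=S)N2CCCC2)oc2ccccc12` differs from compound 2 by chloro in place of hydrogen on an aromatic carbon. Among the compounds with values here, the one measured step with a comparable change puts chloro on the other ring of the shared core: an at least 1.7-fold higher number from compound 2 to compound 3 (0.23 log units; that floor lies within the scatter), a change whose floor sits within the scatter. The step from compound 1 to compound 3 does not bear on this change. A weak compound is therefore expected again, with no step beyond the scatter expected, a 1.3-fold higher number from compound 2 to compound 4 (0.11 log units; within the scatter). The estimate for compound 4 in this assay is 30000 nM, within 10000 nM to 90000 nM.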

Compound 4, half-maximal inhibitory concentration: 700 nM
For compound 4 the middle estimate is 43-fold (1.63 log units) above the measured one; measured number below the stated range.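

In this assay the place of the chloro matters, not just its presence: set on the ring with the oxygen, two atoms from the ring oxygen, it gives a 33-fold lower number from compound 2 to compound 4 (1.52 log units; beyond the scatter) and turns a weak compound into a far stronger one. Compound 3, with chloro on the other ring of the shared core, stands only at a limit of the assay, > 40000 nM in this case. Nothing measured here explains the gain.

From the compounds shown here alone, whether bromo, methyl or methoxy at this position would do the same stays open. So does whether the gain holds with piperidin-1-yl on the thiocarbonyl carbon.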